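This account rests on a few compounds, and the source may have more. Where it says the series, first, only, none or still open, it means among the compounds named here.

In a functional assay on HCT-116 cells (Homo sapiens) for antiproliferative activity, read by MTT assay, with a stated time of 48 h (on this read-out lower numbers stand for stronger inhibition and higher numbers for weaker inhibition), three compounds built on one shared core have been measured. Compound 1 `COc1ccc(CN(C(=O)CSc2nc3ccccc3s2)c2cc(OC)c(OC)c(OC)c2)cc1F` gives 1830 nM, compound 2 `COc1ccc(CN(C(=O)CSc2nc3ccccc3s2)c2cc(OC)c(OC)c(OC)c2)cc1[N+](=O)[O-]` gives 1280 nM, and compound 3 `COc1ccc(CN(C(=O)CSc2nc3ccccc3s2)c2cc(OC)c(OC)c(OC)c2)cc1` gives 426 nM. Compound 3 thus stands with the lowest number of the three: the step of a 4.3-fold lower number from compound 1 to compound 3 (0.63 log units; beyond the scatter) and the step of a 3.0-fold lower number from compound 2 to compound 3 (0.48 log units; beyond the scatter) both lie beyond the scatter, whereas the step of a 1.4-fold lower number from compound 1 to compound 2 (0.16 log units; within the scatter) lies within it.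

Compound 4 `COc1cc(N(Cc2ccc(Cl)cc2)C(=O)CSc2nc3ccccc3s2)cc(OC)c1OC` differs from compound 3 in one place: chloro in place of methoxy on an aromatic carbon. For the measured compounds named here, no measured step touches this exchange directly. The two steps that lie beyond the scatter concern fluoro or nitro giving way to hydrogen on an aromatic carbon of that same ring, and both were modest in size. They show that what sits on that ring can shift the number by a modest amount, but they give no reading of chloro against methoxy. One therefore expects no step beyond the scatter, with a slight lean toward a higher number, and the step of a 1.6-fold higher number from compound 3 to compound 4 (0.22 log units; within the scatter) expresses that expectation. For compound 4 in this assay the estimate is 700 nM, within a range from 250 nM to 2000 nM.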

Compound 4, half-maximal inhibitory concentration: 603000 nM
Compound 4: the middle estimate sits 860-fold (2.94 log units) below what was measured; the measured number lies above the stated range.
By their numbers in this assay, from the lowest: compound 3; then compounds 2 and 1 (each within the scatter of the next); then compound 4.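

For the compounds shown here, replacing 4-methoxybenzyl with 4-chlorobenzyl gives, in this assay, a 1400-fold higher number from compound 3 to compound 4 (3.15 log units; beyond the scatter) and so shows that the group on this aromatic carbon, para to a large group, weighs far more than the fluoro, nitro or hydrogen exchanges seen among the earlier compounds, all of which kept the methoxy group. The gap is just as clear against the other two compounds, with a 470-fold higher number from compound 2 to compound 4 (2.67 log units; beyond the scatter) and a 330-fold higher number from compound 1 to compound 4 (2.52 log units; beyond the scatter), although these two steps also remove the nitro or the fluoro, so that compound 4 stands well apart from all three methoxy compounds. Nothing measured here offers an explanation for so large a step.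

The compounds shown cannot separate what the loss of the methoxy group contributes from what the arrival of the chloro contributes, since none of them carries a plain benzyl group with hydrogen on this carbon. On these data alone, it also remains open whether a hydroxy group, an ethoxy group or an amine on this carbon would keep the number near that of compound 3 at 426 nM or move it toward that of compound 4.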